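A few compounds are considered here, and "the series" means these few. Any claim that something is new, unique, unknown or untested is made for them only; others in the source may bear on it.

Measured so far in an assay on CHO cells for displacement of a labelled ligand from 5-hydroxytryptamine receptor 1D (Homo sapiens); a lower number here means a stronger inhibitor, a higher number a weaker inhibitor:
Compound 1, `CC(C)=CCCN(C)C1CCN(CCCc2c[nH]c3ccc(-n4cnnc4)cc23)CC1`: 2.6 nM
Compound 2, `c1ccc2c(c1)CCC2NC1CCN(CCCc2c[nH]c3ccc(-n4cnnc4)cc23)CC1`: 8.9 nM
Compound 3, `CC(=O)Nc1ccc(CNC2CCN(CCCc3c[nH]c4ccc(-n5cnnc5)cc34)CC2)cc1`: 3 nM

Compound 3 stands second highest of the three numbers; its value and that of compound 1 lie within the scatter of each other, while compound 2 is set apart by a 3.0-fold lower number from compound 2 to compound 3 (0.47 log units; beyond the scatter). Compound 4, `c1ccc(CNC2CCN(CCCc3c[nH]c4ccc(-n5cnnc5)cc34)CC2)cc1`, differs from compound 3 by hydrogen in place of acetamido on an aromatic carbon. Within the data shown here, no measured step removes a group from this aromatic ring; the two steps that exist, a 3.4-fold higher number from compound 1 to compound 2 (0.53 log units; beyond the scatter) and a 3.0-fold lower number from compound 2 to compound 3 (0.47 log units; beyond the scatter), both exchange the whole group on the amine nitrogen and were modest. The change to compound 4 is smaller than either, so a step in this assay of modest size at most is expected, more likely toward a higher number, possibly none beyond the scatter. Compound 4 is therefore estimated at 5 nM, in the range 2 nM to 15 nM, a step of a 1.7-fold higher number from compound 3 to compound 4 (0.22 log units; within the scatter).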

Compound 4, half-maximal inhibitory concentration: 4.6 nM
Beside the measured number, compound 4's estimate is 1.1-fold (0.04 log units) above it, within the range that was stated.
By their numbers in this assay, from the lowest: compounds 1, 3, 4 and 2 (each within the scatter of the next, the first and the last beyond it).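

In this assay, acetamido and hydrogen on this aromatic carbon are not told apart (a 1.5-fold higher number from compound 3 to compound 4 (0.19 log units; within the scatter)). Compound 4 also lies within the scatter of the two compounds with other amine substituents (a 1.9-fold lower number from compound 2 to compound 4 (0.29 log units; within the scatter)) (a 1.8-fold higher number from compound 1 to compound 4 (0.25 log units; within the scatter)), although those two remain beyond the scatter of each other. No measurement shown here accounts for these results.

Going by these compounds, whether a carboxylic acid, an amine or a methoxy group on this aromatic carbon would separate from hydrogen remains open.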